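A few compounds are considered here, and "the series" means these few. Any claim that something is new, unique, unknown or untested is made for them only; others in the source may bear on it.

Measured so far in a physicochemical assay for solubility, at pH 6.8 (a lower number here means a less soluble compound, a higher number a more soluble compound), are these compounds:

Compound 1 (`Nc1ccc(CNC(=O)Nc2ccc(CN3C(=O)c4ccccc4C3=O)cc2)cn1`) gives < 5000 nM as a limit
Compound 2 (`O=C(NCc1cccnc1)Nc1ccc(CNC(=O)c2ccc(CN3CCNCC3)cc2)cc1`) gives > 1000000 nM as a limit
Compound 3 (`CCC(=O)N[C@@H](C)c1ccc(NC(=O)[C@H]2C[C@@H]2c2cccnc2)cc1`) gives 54000 nM as a number

Compound 3 is the only one of the three with an actual number in this assay and so is the one firm reference point. The entries for compound 1 and compound 2 are limits, not numbers.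

Compound 4 (`C[C@H](NC(=O)CC(F)(F)F)c1ccc(NC(=O)[C@H]2C[C@@H]2c2cccnc2)cc1`) has yet to be measured. It has trifluoromethyl in place of methyl on a saturated chain carbon bound to a carbonyl carbon, so propanoylamino becomes ((2,2,2-trifluoroethyl)carbonyl)amino.

Among the compounds with values here, no measured pair here shows this change, so the expectation starts from compound 3 at 54000 nM and stays cautious. A modest fall in the read-out is expected, an estimated 2.2-fold lower number from compound 3 to compound 4 (0.33 log units; beyond the scatter) and no large shift. For compound 4 the estimated solubility is 25000 nM with 9000 nM to 60000 nM as the expected range.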

Compound 4, solubility: 41000 nM
The estimate for compound 4 lay 1.6-fold (0.21 log units) below the measured number; measured number inside the range.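

In this assay, within the data shown here, compounds 3 and 4 form the first measured pair that differs in one place: trifluoromethyl in place of methyl on a saturated chain carbon bound to a carbonyl carbon gives a 1.3-fold lower number from compound 3 to compound 4 (0.12 log units; within the scatter) in this pair. This position therefore takes a group of 4 heavy atoms where 1 stood, with a step that stays within the scatter of repeat measurements, and both compounds give actual numbers rather than limits. No measurement shown here bears on the reason for this result.

On these data alone, whether an amine, a carboxylic acid or a longer chain at this place would leave the read-out just as steady remains open. One pair also cannot show whether the same change would behave alike on another core.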